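Swapping a chlorinated aniline for a phenol

This account rests on a few compounds, and the source may have more. Where it says the series, first, only, none or still open, it means among the compounds named here.

Of the compounds shown here, three built on one shared core have been tested. Compound 1 `O=C(CSC(=S)N[C@H]1CCOC1=O)Nc1ccccc1F` is the one with a fluorine on the phenyl ring; in a functional assay on MCF7 cells (Homo sapiens) for cytotoxicity, read by MTT assay, with a stated time of 72 h (on this read-out lower numbers stand for stronger inhibition and higher numbers for weaker inhibition), compound 1 gives 28600 nM. Compound 2 `O=C(CSC(=S)N[C@H]1CCOC1=O)Nc1cccc(Cl)c1` gives 46600 nM in this assay, and compound 3 `O=C(CSC(=S)N[C@H]1CCOC1=O)Nc1ccccc1Cl` gives 90800 nM. Compound 3 thus shows the highest number of the three, but its distance to compound 2 stays within the scatter (a 1.9-fold higher number from compound 2 to compound 3 (0.29 log units; within the scatter)), whereas the step of a 3.2-fold higher number from compound 1 to compound 3 (0.50 log units; beyond the scatter) reaches beyond it. The step of a 1.6-fold higher number from compound 1 to compound 2 (0.21 log units; within the scatter) is likewise within the scatter.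

Compound 4 `O=C(CSC(=S)N[C@H]1CCOC1=O)Nc1ccc(O)cc1` is not yet measured. It differs from compound 3 in one place: 4-hydroxyphenyl in place of 2-chlorophenyl on an amide-type nitrogen. The measured steps that bear on this are the three exchanges of the group on the amide-type nitrogen, and all of them were small, at most modest. None of them introduces a hydroxyl group, so the direction is uncertain. Since the earlier exchanges moved the numbers little, a small step is expected, if anything toward a lower number, as a 1.8-fold lower number from compound 3 to compound 4 (0.26 log units; within the scatter). For compound 4 in this assay the estimate is 50000 nM, with a range from 15000 nM to 160000 nM.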

Compound 4, half-maximal inhibitory concentration: > 128000 nM
Compound 4: only a limit was reported; the forecaster's own chance of this, stated with the estimate: 15%; middle value at least 2.5-fold (0.40 log units) from the limit.
By their numbers in this assay, from the lowest: compounds 1, 2 and 3 (each within the scatter of the next, the first and the last beyond it). At a limit, above all of these: compound 4.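

In this assay compound 4 carries only a limit of the assay, not a number: the limit of > 128000 nM in this assay, at which 1 of the 4 values shown sits. On the amide-type nitrogen, replacing the halogen-bearing phenyl groups with 4-hydroxyphenyl gives two steps beyond the scatter, an at least 2.7-fold higher number from compound 2 to compound 4 (0.43 log units; beyond the scatter) and an at least 4.4-fold higher number from compound 1 to compound 4 (0.65 log units; beyond the scatter), while the floor of the third step, an at least 1.4-fold higher number from compound 3 to compound 4 (0.14 log units; that floor lies within the scatter), stays within it, so compound 4 cannot yet be told apart from compound 3. The earlier compounds shown here showed only exchanges among halogen-bearing phenyl groups, and this first group without a halogen, which brings one hydrogen-bond donor and one hydrogen-bond acceptor, gives no lower number than any of them.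

Compound 4 changes both the substituent and its place on the ring relative to compounds 1, 2 and 3, and the compounds shown cannot separate these two changes. Going by these compounds, whether a phenyl ring carrying a methoxy group or an amine would fall with compound 4 or with the three halogen-bearing compounds also stays open.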